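A Benzyl-to-Propyl Amide Change in a Cytotoxicity Series

The source may report more compounds than this note shows. Statements on the series, on what has been measured and on what is new or still open speak of the compounds shown alone.

Compound 1, `C=CC1=C(C(=O)NCc2ccccc2)C(c2ccc(OC)cc2)OC1`: > 100000 nM
Compound 2, `C=CC1=C(C(=O)NCc2ccccc2)C(c2ccc(F)cc2)OC1`: > 100000 nM

Compound 1 `C=CC1=C(C(=O)NCc2ccccc2)C(c2ccc(OC)cc2)OC1` was examined in a functional assay on A549 cells (Homo sapiens) for cytotoxicity, read by MTT assay, with a stated time of 24 h; on this read-out lower numbers stand for stronger inhibition and higher numbers for weaker inhibition. In this assay compound 1 returns > 100000 nM, which is a limit of the assay and not a number. Compound 2 `C=CC1=C(C(=O)NCc2ccccc2)C(c2ccc(F)cc2)OC1` likewise gives > 100000 nM in this assay, again a limit. Within the data shown here, the only measured step, a step that the two limits leave unreadable from compound 1 to compound 2, is therefore unreadable, and compound 1 stands at the limit together with its companion, as the record the limit of > 100000 nM in this assay, at which 2 of the 2 values shown sit, shows.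

Compound 3 `C=CC1=C(C(=O)NCCC)C(c2ccc(OC)cc2)OC1` has not yet been measured in this assay. Its difference from compound 1 is ethyl in place of phenyl on a saturated chain carbon bound to an amide-type nitrogen. Among the measured compounds shown here, no measured step touches this saturated chain carbon bound to an amide-type nitrogen, and the one measured step in the set gives no readable size. Nothing in the measured data points toward a move away from the limit, so compound 3 is expected to remain there, with the step of a number no higher from compound 1 to compound 3 (the limit leaves the size open) estimated as effectively none beyond the scatter. Compound 3 is accordingly estimated at 100000 nM, within a range from 40000 nM to 300000 nM, most likely reported again only as a limit.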

Compound 3, half-maximal inhibitory concentration: > 100000 nM
Compound 3 ended at the assay's limit; the forecaster's own chance of this, stated with the estimate: 85%; the middle value lies on the limit itself.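

In this assay compound 3 gives > 100000 nM, which is a limit and not a number. Among these compounds, compound 1 also stands at a limit, so no step from it to compound 3 can be read. The compounds shown leave open whether benzyl to propyl changes the read-out at all, since all of them sit at one limit: the limit of > 100000 nM in this assay, at which 3 of the 3 values shown sit.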